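Bromo for Methyl on a Fused Quinolone Core

The compounds below may be only part of what the source reports. "The series", "measured", "known", "first", "only" and "open" are said of these compounds alone.

Compound 3 `COc1cc2[nH]c(C)c(C)c(=O)c2cc1Cl` stands at the bottom of the three numbers recorded in an ADME assay for permeability, using PAMPA, at pH 4; on this read-out higher numbers stand for higher permeability and lower numbers for lower permeability: compound 3 gives 37 10^-6 cm/s, compound 1 `Cc1[nH]c2ccc(Cl)cc2c(=O)c1Br` gives 84.5 10^-6 cm/s and compound 2 `CCc1c(C)[nH]c2cc(OC)c(Cl)cc2c1=O` gives 96.4 10^-6 cm/s. Among the compounds with values here, the one single-point step among the measured compounds, a 2.6-fold lower number from compound 2 to compound 3 (0.42 log units; beyond the scatter), concerns a saturated chain carbon and therefore does not speak directly to the change that leads to compound 4 `COc1cc2[nH]c(C)c(Br)c(=O)c2cc1Cl`.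

That change is bromo in place of methyl on an aromatic carbon. Within the data shown here, no measured pair isolates this exchange. Among the measured compounds shown here, compound 1 does carry a bromo at the corresponding position, but it also lacks the methoxy of compound 3, so the two compounds differ in two places; one can say only that compound 1 gives 84.5 10^-6 cm/s in this assay while compound 3 gives 37 10^-6 cm/s.

With that as the sole point of reference, compound 4 is expected to move up by a 1.5-fold higher number from compound 3 to compound 4 (0.17 log units; within the scatter), a step that may or may not clear the scatter. The estimate for compound 4 in this assay is therefore 55 10^-6 cm/s, with a plausible range from 28 10^-6 cm/s to 110 10^-6 cm/s; the measured value is awaited.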

Compound 4, apparent permeability: 125 10^-6 cm/s
Estimate against measurement, compound 4: 2.3-fold (0.36 log units) below; measured number outside the range, above it.
By their numbers in this assay, from the lowest: compound 3; then compounds 1, 2 and 4 (each within the scatter of the next).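

With bromo in place of methyl on an aromatic carbon, the exchange now has a measured pair of its own in this assay (a 3.4-fold higher number from compound 3 to compound 4 (0.53 log units; beyond the scatter)), and that step lies beyond the scatter, so replacing this single heavy atom on the shared core is enough to register at this position, ortho to a methyl group and two atoms from the ring nitrogen. Within the data shown here, the same carbon carrying ethyl or bromo gives numbers that cannot be separated (a 1.3-fold higher number from compound 2 to compound 4 (0.11 log units; within the scatter)), which leaves compound 3, with its methyl, as the one compound of these three set apart by steps beyond the scatter. With bromo in place, methoxy in place of hydrogen on an aromatic carbon also stays within the scatter (a 1.5-fold higher number from compound 1 to compound 4 (0.17 log units; within the scatter)), so that pair shows no separable change.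

No measured evidence at hand accounts for any of these steps. Also open, going by these compounds, is how an amine, a carboxylic acid or a longer chain on this carbon would read in this assay, and whether the methoxy step would stay within the scatter with methyl or ethyl on that carbon instead of bromo.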